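Extending the alkyl chain: expected cytotoxicity on Vero cells

The source may hold more compounds than are shown below. What is called first, only, known or untested is meant among the compounds shown, and "the series" means these compounds.

Compound 1 `CCCCNc1nc(=O)c2cc([N+](=O)[O-])cc([N+](=O)[O-])c2s1` — in an ADME assay on Vero cells (Chlorocebus sabaeus) for cytotoxicity, read by MTT assay, with a stated time of 72 h (a lower number here means a stronger inhibitor, a higher number a weaker inhibitor), compound 1 gives "not determined" (no result reported).
Compound 2 `CCNc1nc(=O)c2cc(C(F)(F)F)cc([N+](=O)[O-])c2s1` — in this assay compound 2 gives > 100000 nM, a limit of the assay and not a number.
Compound 3 `CCCNc1nc(=O)c2cc(C(F)(F)F)cc([N+](=O)[O-])c2s1` — in this assay compound 3 gives > 100000 nM, again a limit of the assay.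

Compound 3 therefore stands only at a limit, and compound 2 sits with it at the limit of > 100000 nM in this assay, at which 2 of the 3 values shown sit, while compound 1 has no result. Going by the values given here, the single measured step that resembles the change of interest, a step that the two limits leave unreadable from compound 2 to compound 3, cannot be sized. Compound 4 `CCCCNc1nc(=O)c2cc(C(F)(F)F)cc([N+](=O)[O-])c2s1` differs from compound 3 by methyl in place of hydrogen on a saturated chain carbon, three bonds along the chain from a nitrogen on an aromatic ring. With no readable step to lean on, the expectation is that compound 4 stays at the limit, a step that the limit leaves unreadable from compound 3 to compound 4. Compound 4 is expected to give 150000 nM, between 50000 nM and 500000 nM.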

Compound 4, half-maximal inhibitory concentration: > 100000 nM
Compound 4: no number, only a limit (the forecaster's own chance of this, stated with the estimate: 85%); the middle value does not contradict the limit.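

No step can be read among compound 2, compound 3 and compound 4, since each result is a limit of the assay and not a number: the limit of > 100000 nM in this assay, at which 3 of the 4 values shown sit.

In this assay, from the compounds shown here alone, the size of any effect of lengthening the chain from ethyl to butyl stays open.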